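The compounds below may be only part of what the source reports. "The series", "measured", "known", "first", "only" and "open" are said of these compounds alone.

The measured compounds, each read in a functional assay on K562 cells (Homo sapiens), read by MTT assay, with a stated time of 72 h; on this read-out higher numbers stand for weaker inhibition and lower numbers for stronger inhibition:

compound 1, `COc1nc(N)nc2c1c(-c1cccs1)cn2[C@@H]1O[C@H](CO)[C@@H](O)[C@H]1O`, gives > 20000 nM, which is a limit of the assay and not a number.
compound 2, `Nc1nc2c(c(-c3cccs3)cn2[C@@H]2O[C@H](CO)[C@@H](O)[C@H]2O)c(=O)[nH]1`, gives > 20000 nM, again only a limit.
compound 3, `COc1nc(N)nc2c1c(-c1ccoc1)cn2[C@@H]1O[C@H](CO)[C@@H](O)[C@H]1O`, gives > 20000 nM, again only a limit.

Compounds 1 and 3 share a core and differ in one place: furan-3-yl in place of thiophen-2-yl on an aromatic carbon. The step between them in this assay, a step that the two limits leave unreadable from compound 1 to compound 3, has no readable size, since both values sit at the limit of > 20000 nM in this assay, at which 3 of the 3 values shown sit. Compound 2 carries a different core; how its core differs from that of compound 1 is not broken down here, and with compound 2 also stopping at the limit, the three measured values show nothing that separates any of them.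

Compound 4, `Nc1nc2c(c(-c3ccoc3)cn2[C@@H]2O[C@H](CO)[C@@H](O)[C@H]2O)c(=O)[nH]1`, has not yet been measured. It stands to compound 2 exactly as compound 3 stands to compound 1, with the same change made at the same place: furan-3-yl in place of thiophen-2-yl on an aromatic carbon. Among the measured compounds shown here, the only earlier instance of this change, the step from compound 1 to compound 3, gave no size, and nothing among the measured compounds points to a strong inhibitor. An estimate for compound 4 therefore gives the step that the limit leaves unreadable from compound 2 to compound 4, resting on a step that the two limits leave unreadable from compound 1 to compound 3 and on all three measured values sitting at the limit of > 20000 nM in this assay, at which 3 of the 3 values shown sit. The estimate for compound 4 in this assay is 40000 nM, with a range from 15000 nM to 150000 nM, and the most likely outcome is that the assay again reports only a limit.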

Compound 4, half-maximal inhibitory concentration: 19600 nM
For compound 4 the middle estimate is 2.0-fold (0.31 log units) above the measured one, and the stated range covers the measured number.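

In this assay, among the compounds shown here, putting furan-3-yl in place of thiophen-2-yl on the core of compound 2 gives an at least 1.0-fold lower number from compound 2 to compound 4 (0.00 log units; that floor lies within the scatter), so the only thing the step establishes is a floor that cannot be told apart from no change at all. From the compounds shown here alone, compound 4 gives 19600 nM, a measured number rather than a limit, but this does not show that furan-3-yl does better than thiophen-2-yl on this core, since the true value of compound 2 remains unknown. For the compounds shown here, the same change on the core of compound 1 cannot be read, so the two cores offer no pair of sizes to compare, and the data neither show that the change carries from one core to the other nor show that it fails to, with the values of the other compounds stopping here: the limit of > 20000 nM in this assay, at which 3 of the 4 values shown sit.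

The compounds shown leave open whether an amine, a carboxylic acid or a longer alkyl chain on that aromatic carbon, in place of these two five-membered aromatic rings, would give a value clearly separated from the limit in this assay. They also leave open whether either core can give strong inhibition in this assay at all.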